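The compounds below may be only part of what the source reports. "The series", "measured", "known", "first", "only" and "open" are said of these compounds alone.

Measured in a functional assay on MDA-MB-231 cells (Homo sapiens) for antiproliferative activity, read by MTT assay, with a stated time of 48 h; on this read-out lower numbers stand for stronger inhibition and higher numbers for weaker inhibition:
- compound 1 `COc1cc(/C=N/c2c(C#N)ncn2-c2ccc(F)cc2)cc(OC)c1OC`: 18700 nM
- compound 2 `N#Cc1ncn(-c2ccc(F)cc2)c1/N=C/c1ccc([N+](=O)[O-])cc1`: 13400 nM
- compound 3 `N#Cc1ncn(-c2ccc(F)cc2)c1/N=C/c1cc([N+](=O)[O-])ccc1O`: 17200 nM

The three compounds share one core and differ in the groups on the ring that carries the methoxy groups in compound 1. Compound 1 stands level with the other two, since its value lies within the usual scatter of both. Their numbers therefore cannot be put in a meaningful order.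

The next compound is compound 4 `COc1ccc(/C=N/c2c(C#N)ncn2-c2ccc(F)cc2)cc1OC`, which has not yet been measured in this assay. It differs from compound 1 in one place, with hydrogen in place of methoxy on an aromatic carbon. Among the measured compounds shown here, no measured pair of compounds shows this single change, so there is no direct precedent for its size.

For the measured compounds named here, the only guide is the spread of the measured values. Compound 2 at 13400 nM and compound 3 at 17200 nM both stay within the scatter of compound 1, even though their ring groups differ from its methoxy groups. On that basis, no step beyond the scatter is expected, in either direction. The expected change is small, a 1.1-fold lower number from compound 1 to compound 4 (0.05 log units; within the scatter). For compound 4 the estimated value is 16500 nM, with an expected range from 9000 nM to 31000 nM.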

Compound 4, half-maximal inhibitory concentration: 4270 nM
Compound 4: the middle estimate sits 3.9-fold (0.59 log units) above what was measured, and the stated range ends above it.
By their numbers in this assay, from the lowest: compound 4; then compounds 2, 3 and 1 (each within the scatter of the next).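

In this assay, replacing one methoxy group with hydrogen gives a 4.4-fold lower number from compound 1 to compound 4 (0.64 log units; beyond the scatter), so this ring position, ortho to a methoxy group and meta to a large group, does not tolerate every change without effect on the number. The earlier compounds shown here could not show this: each differs from the others in more than one place, and their values lie within the scatter of one another, whereas this pair isolates a single small change, the loss of 2 heavy atoms (1 carbon, 1 oxygen) and 1 hydrogen-bond acceptor. No measurement shown here explains why this change lowers the number.

Only methoxy and hydrogen are shown at this position, so it remains open whether an amine, a chlorine atom or a longer chain such as ethoxy would give a number closer to that of compound 1 or compound 4. Among the compounds shown here, whether removing a further methoxy group from compound 4 would lower the number again also stays open, and this one pair is the only evidence for the change.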